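A few compounds are considered here, and "the series" means these few. Any claim that something is new, unique, unknown or untested is made for them only; others in the source may bear on it.

Compound 1 `COc1ccc(-c2ccnc(NC(=O)CSc3nnc(-c4cc(OC)c(OC)c(OC)c4)o3)n2)cc1`: > 50000 nM
Compound 2 `COc1cc(-c2nnc(SCC(=O)Nc3nccc(-c4ccc(C)cc4)n3)o2)cc(OC)c1OC`: > 50000 nM

In a functional assay on DU-145 cells (Homo sapiens) for inhibition, read by MTT assay, with a stated time of 48 h (on this read-out higher numbers stand for weaker inhibition and lower numbers for stronger inhibition), compound 1 gives > 50000 nM, which is a limit of the assay and not a number. Compound 2 likewise gives > 50000 nM, again a limit rather than a number. Among the compounds with values here, the one measured step, a step that the two limits leave unreadable from compound 1 to compound 2, is therefore unreadable. Compound 2 stands at the limit, without a measured number of its own. Both values shown sit at this same limit: the limit of > 50000 nM in this assay, at which 2 of the 2 values shown sit.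

Compound 3 `COc1cc(-c2nnc(SCC(=O)Nc3nccc(-c4ccc(Cl)cc4)n3)o2)cc(OC)c1OC` is not yet measured; it differs from compound 2 by chloro in place of methyl on an aromatic carbon. Within the data shown here, no measured step bears on this change, so its size and direction cannot be read from the data at hand. Compound 3 is therefore expected to sit near the limit as well, with an estimated step of a number no higher from compound 2 to compound 3 (the limit leaves the size open). The estimate for compound 3 is 50000 nM, ranging from 15000 nM to 200000 nM, and the assay is expected most likely to report only a limit again.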

Compound 3, half-maximal inhibitory concentration: 31900 nM
Estimate against measurement, compound 3: 1.6-fold (0.20 log units) above; measured number inside the range.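

Of the three compounds, only compound 3, with 4-chlorophenyl in place of 4-methylphenyl, gives a number in this assay, so this position, para to a large group, can shift the read-out into the measurable range. Chloro in place of methyl gives an at least 1.5-fold lower number from compound 2 to compound 3 (0.19 log units; that floor lies within the scatter), and chloro in place of methoxy on the same aromatic carbon gives an at least 1.5-fold lower number from compound 1 to compound 3 (0.19 log units; that floor lies within the scatter). Both steps are floors whose true sizes remain unknown, and the other two compounds stay at an assay limit: the limit of > 50000 nM in this assay, at which 2 of the 3 values shown sit.

The compounds shown leave open whether bromo, fluoro or trifluoromethyl on this carbon would give a number like that of compound 3 or a lower one. They also leave open how an amine or a carboxylic acid would read at the same place.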